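This account rests on a few compounds, and the source may have more. Where it says the series, first, only, none or still open, it means among the compounds named here.

Among the measured compounds shown here, in a functional assay on BGC-823 cells (Homo sapiens) for inhibition, read by MTT assay, with a stated time of 72 h (on this read-out lower numbers stand for stronger inhibition and higher numbers for weaker inhibition), compound 2 `O=C1/C(=C\c2ccccc2)c2c(ncn2COCc2ccccc2)CCN1Cc1ccc(Cl)cc1` gives 75700 nM and holds the higher of the two numbers so far, with compound 1 `O=C1/C(=C\c2ccccc2)c2c(ncn2COCc2ccccc2)CCN1Cc1ccccc1` at 20400 nM on the same read-out. Compound 3 `COc1ccc(CN2CCc3ncn(COCc4ccccc4)c3/C(=C/c3ccccc3)C2=O)cc1` has methoxy in place of chloro on an aromatic carbon, with methoxy in place of chloro on an aromatic carbon as the counted difference. For the measured compounds named here, the only measured step at this place is a 3.7-fold higher number from compound 1 to compound 2 (0.57 log units; beyond the scatter) for chloro in place of hydrogen, so a modest move toward a lower number is expected in this assay for compound 3, although no methoxy value exists yet. The expected change is a 2.2-fold lower number from compound 2 to compound 3 (0.34 log units; beyond the scatter) and its direction rests on that single step. Compound 3 is estimated at 35000 nM within a range of 14000 nM to 90000 nM in this series.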

Compound 3, half-maximal inhibitory concentration: 71600 nM
Estimate against measurement, compound 3: 2.0-fold (0.31 log units) below, and the stated range covers the measured number.
By their numbers in this assay, from the lowest: compound 1; then compounds 3 and 2 (each within the scatter of the next).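

In this assay the 4-chlorobenzyl and 4-methoxybenzyl compounds cannot be told apart, with a 1.1-fold lower number from compound 2 to compound 3 (0.02 log units; within the scatter) as the step between them. Methoxy in place of hydrogen gives a 3.5-fold higher number from compound 1 to compound 3 (0.55 log units; beyond the scatter) and so provides a second substituent at this aromatic carbon that leaves the number on the higher side of compound 1, as chloro does. No evidence is available on why these values fall as they do. Still open, from the compounds shown here alone, is whether an amine or a carboxylic acid at this carbon, or a longer chain in place of methoxy, would stay level with compound 2 and compound 3 or return toward compound 1.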